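Positional shift of the phenyl hydroxy in the anilino-nitrile series

A few compounds are considered here, and "the series" means these few. Any claim that something is new, unique, unknown or untested is made for them only; others in the source may bear on it.

Measured so far in a functional assay on HUVEC cells (Homo sapiens), read by fluorescence and microscopy, with a stated time of 6 h, tested at 10 uM; a higher number here means a weaker effect of the compound at the concentration tested, a lower number a stronger effect:
compound 1 `COc1cc2sc(Nc3ccccc3)c(C#N)c2cc1OC` gives 77%
compound 2 `N#Cc1c(Nc2ccccc2)sc2ccccc12` gives 81%
compound 3 `COc1cc2sc(Nc3cccc(O)c3)c(C#N)c2cc1OC` gives 11%

Compound 3 stands lowest of the three numbers in this assay; the nearest is compound 1, the furthest compound 2, both beyond the scatter. Among the compounds with values here, the only step that touches it is a number 66 percentage points lower from compound 1 to compound 3 (beyond the scatter), which is large. Compound 4 `COc1cc2sc(Nc3ccc(O)cc3)c(C#N)c2cc1OC` differs from compound 3 by 4-hydroxyphenyl in place of 3-hydroxyphenyl on a nitrogen on an aromatic ring. Within the data shown here, no measured pair shows a hydroxy moved from one place to another on that ring, so the step from compound 3 to compound 4 is expected with little support. The hydroxy stays, so compound 4 is expected to keep a low number, though the strong value of compound 3 may not fully carry over; the expected step is a number 19 percentage points higher from compound 3 to compound 4 (beyond the scatter). For compound 4 the expected value in this assay is 30%, between 5% and 75%.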

Compound 4, a percentage reported as activity, at one concentration (the size of the read-out at that concentration, not a potency): 0%
Compound 4: the middle estimate sits 30 percentage points above what was measured; the measured number lies below the stated range.
By their numbers in this assay, from the lowest: compound 4; then compound 3; then compounds 1 and 2 (each within the scatter of the next).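

In this assay, 4-hydroxyphenyl in place of 3-hydroxyphenyl on the nitrogen gives a number 11 percentage points lower from compound 3 to compound 4 (beyond the scatter), so the strong effect does not depend on the 3-hydroxyphenyl arrangement. Hydroxy in place of hydrogen also gives a number 77 percentage points lower from compound 1 to compound 4 (beyond the scatter), which shows that the large drop occurs with both hydroxyphenyl groups. Nothing available explains the difference between these two groups.

Going by these compounds, whether an amine or a carboxylic acid on the phenyl ring would match the hydroxy remains open. Also open, on these data alone, is whether the methoxy groups on the core are needed once the hydroxy is present.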